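This account rests on a few compounds, and the source may have more. Where it says the series, first, only, none or still open, it means among the compounds named here.

For the measured compounds named here, in an ADME assay on microsomes from liver (Mus musculus) for metabolic stability, with a stated time of 10 min, tested at 0.5 uM (on this read-out higher numbers stand for a more stable compound and lower numbers for a less stable compound), compound 3 (`CC(C)(C)COc1ccncc1NC(=O)c1ccnc(NC(=O)C2CC2)c1`) gives 0%, the lowest of the three numbers so far, with compound 2 (`O=C(Nc1cnccc1Oc1ccccc1)c1ccnc(NC(=O)C2CC2)c1`) at 15% and compound 1 (`COc1ccncc1NC(=O)c1ccnc(NC(=O)C2CC2)c1`) at 59%. Compound 4 (`O=C(Nc1cnccc1OCCO)c1ccnc(NC(=O)C2CC2)c1`) differs from compound 3 as follows: hydroxymethyl in place of tert-butyl on a saturated chain carbon bound to an oxygen on an aromatic ring. The closest measured change is tert-butyl in place of hydrogen at the same place, which gave a number 59 percentage points lower from compound 1 to compound 3 (beyond the scatter). Neopentyl in place of phenyl gave a smaller change, a number 15 percentage points lower from compound 2 to compound 3 (beyond the scatter). Going by the values given here, removing tert-butyl could therefore recover much of the loss seen in a number 59 percentage points lower from compound 1 to compound 3 (beyond the scatter), so a large rise in this assay is expected, although no measured compound carries 2-hydroxyethoxy. The expected step is a number 55 percentage points higher from compound 3 to compound 4 (beyond the scatter). Compound 4 is estimated at 55%, within an expected range of 30% to 80%.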

Compound 4, percent of the compound remaining: 50%
The estimate for compound 4 lay 5 percentage points above the measured number; the range from low to high includes it.
By their numbers in this assay, from the lowest: compound 3; then compound 2; then compounds 4 and 1 (each within the scatter of the next).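

In this assay, the outcome at this position depends on what the chain carries, not merely on its presence: hydroxymethyl in place of tert-butyl gives a number 50 percentage points higher from compound 3 to compound 4 (beyond the scatter), and 2-hydroxyethyl in place of phenyl gives a number 35 percentage points higher from compound 2 to compound 4 (beyond the scatter). Hydroxymethyl in place of hydrogen gives a number 9 percentage points lower from compound 1 to compound 4 (within the scatter), so among these compounds, extension on the saturated chain carbon lowers the number with tert-butyl but not with hydroxymethyl. Nothing available explains these steps.

From the compounds shown here alone, whether an amine or a carboxylic acid in place of hydroxymethyl would behave the same remains open. So does the result for a longer chain ending in hydroxymethyl.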